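This account rests on a few compounds, and the source may have more. Where it says the series, first, only, none or still open, it means among the compounds named here.

Measured in a functional assay on MCF7 cells (Homo sapiens) for inhibition; a lower number here means a stronger inhibitor, a higher number a weaker inhibitor:
- compound 1 `C=CCOC1=CC(=O)S[C@]1(C)CCCCCC`: > 50 ug/mL, a limit
- compound 2 `C=CCOC1=CC(=O)S[C@]1(C)CCCCCCCC`: > 50 ug/mL, a limit

Compound 2 has no number, only the limit > 50 ug/mL. The evidence so far is the limit of > 50 ug/mL in this assay, at which 2 of the 2 values shown sit.

Compound 3 `CCCCCCCC[C@@]1(C)SC(=O)C=C1OC(=O)CC` differs from compound 2 by propanoyl in place of allyl on an oxygen on an unsaturated carbon. Going by the values given here, the only measured step is a step that the two limits leave unreadable from compound 1 to compound 2. It lies on the chain, not on this oxygen, so it offers no size or direction to carry over into this assay.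

The expectation therefore rests on compound 2 and its limit of > 50 ug/mL. The expected change is a step that the limit leaves unreadable from compound 2 to compound 3. For compound 3 the estimated value is 60 ug/mL, with an expected range of 25 ug/mL to 120 ug/mL.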

Compound 3, half-maximal inhibitory concentration: 22.6 ug/mL
Compound 3: the middle estimate sits 2.7-fold (0.42 log units) above what was measured; measured number outside the range, below it.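

In this assay, propanoyl in place of allyl on this oxygen gives an at least 2.2-fold lower number from compound 2 to compound 3 (0.34 log units; beyond the scatter), so the oxygen on an unsaturated carbon is a place where a change can be read. Going by these compounds alone, compound 3 gives 22.6 ug/mL, the first actual number, while the step along the chain between the two earlier compounds cannot be read. Going by these compounds, compound 2 has only a limit, so the step's full size stays unknown.

Open, on these data alone, is whether acetyl, butanoyl or a carbamate on this oxygen would behave like propanoyl. Also open, as far as these compounds go, is whether the shorter chain of compound 1 would give a readable number with propanoyl on this oxygen.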